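Methoxy in Place of Methyl: A Small Change Expected

The source may report more compounds than this note shows. Statements on the series, on what has been measured and on what is new or still open speak of the compounds shown alone.

Of the compounds shown here, two have so far been tested in a functional assay on cells for inhibition of growth hormone secretagogue receptor type 1 (Homo sapiens), read by FLIPR and calcium flux; a lower number here means that less compound is needed, a higher number that more compound is needed for the effect. Compound 2 `Cc1ccccc1COC[C@@H](NC(=O)C(C)(C)N)c1nnnn1CCOC(=O)NCCCCO` gives 0.51 nM. Going by the values given here, its only companion is compound 1 `CC(C)(N)C(=O)N[C@H](COCc1ccccc1C(F)(F)F)c1nnnn1CCOC(=O)NCCCCO`, which in this assay gives 0.72 nM; the move from one to the other, a 1.4-fold lower number from compound 1 to compound 2 (0.15 log units; within the scatter), so the two compounds stand level with each other. Compound 3 `COc1ccccc1COC[C@@H](NC(=O)C(C)(C)N)c1nnnn1CCOC(=O)NCCCCO` differs from compound 2 in one place: methoxy in place of methyl on an aromatic carbon. Among the compounds with values here, the single measured step, which exchanged trifluoromethyl for methyl at this same aromatic carbon, changed the number no more than the scatter allows, and no measured step involves a methoxy group, so there is no direct precedent for this exchange. On that basis the number for compound 3 is expected to remain near that of compound 2, the expected step being a 1.2-fold higher number from compound 2 to compound 3 (0.07 log units; within the scatter). Compound 3 is therefore estimated at 0.6 nM, most likely between 0.25 nM and 1.5 nM.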

Compound 3, half-maximal effective concentration: 1.11 nM
For compound 3 the middle estimate is 1.9-fold (0.27 log units) below the measured one, within the range that was stated.
By their numbers in this assay, from the lowest: compounds 2, 1 and 3 (each within the scatter of the next, the first and the last beyond it).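

At this aromatic carbon, ortho to a large group, the choice of group can now be seen to matter in this assay: methoxy in place of methyl gives a 2.2-fold higher number from compound 2 to compound 3 (0.34 log units; beyond the scatter), a modest step but the first here to pass beyond the scatter. Methoxy in place of trifluoromethyl gives a 1.5-fold higher number from compound 1 to compound 3 (0.19 log units; within the scatter), so compound 1 and compound 3 stand level, and only the methyl and methoxy pair is told apart. No measurement on hand accounts for that step.

The compounds shown leave open how other groups at this carbon, such as an amine, a chlorine atom or the longer ethoxy chain, would compare with these three. Also open, going by these compounds, is whether methoxy in place of methyl would give a similar step elsewhere on the shared core.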